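A few compounds are considered here, and "the series" means these few. Any claim that something is new, unique, unknown or untested is made for them only; others in the source may bear on it.

Compound 1, `CC(C)[C@H](NC(=O)COc1cccc2ccccc12)C(=O)N[C@@H](CC(=O)O)C(=O)CSc1nc2ccccc2[nH]1`, gives in a functional assay on Jurkat cells (Homo sapiens) for inhibition (on this read-out lower numbers stand for stronger inhibition and higher numbers for weaker inhibition), a value of > 200000 nM, which is a limit of the assay.
Compound 2, `CC(C)[C@H](NC(=O)COc1cccc2ccccc12)C(=O)N[C@@H](CC(=O)O)C(=O)COc1nc2ccccc2[nH]1`, gives in this assay a value of > 200000 nM, also a limit of the assay.
Compound 3, `CC(C)[C@H](NC(=O)COc1cccc2ccccc12)C(=O)N[C@@H](CC(=O)O)C(=O)COc1ccccn1`, gives in this assay a value of > 200000 nM, again a limit of the assay.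

Compound 3 therefore stands only at the limit of > 200000 nM in this assay, at which 3 of the 3 values shown sit. Compound 4, `Cc1cc(C)nc(SCC(=O)[C@H](CC(=O)O)NC(=O)[C@@H](NC(=O)COc2cccc3ccccc23)C(C)C)n1`, differs from it in one place: (4,6-dimethylpyrimidin-2-yl)sulfanyl in place of (pyridin-2-yl)oxy on a saturated chain carbon bound to a carbonyl carbon. The measured steps that touch this position, a step that the two limits leave unreadable from compound 1 to compound 3, a step that the two limits leave unreadable from compound 2 to compound 3 and a step that the two limits leave unreadable from compound 1 to compound 2, all end at limits and give no readable size, so no direction beyond the scatter can be drawn from them. The step from compound 3 to compound 4 is therefore expected to be a number no higher from compound 3 to compound 4 (the limit leaves the size open). Compound 4 is estimated at 200000 nM, within a range from 50000 nM to 1000000 nM, most likely again reported only as a limit.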

Compound 4, half-maximal inhibitory concentration: > 200000 nM
Compound 4 ended at the assay's limit (the forecaster's own chance of this, stated with the estimate: 80%); the middle value sits exactly at the limit.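

No step can be read among compound 1, compound 2, compound 3 and compound 4, because each ends at a limit and not a number: the limit of > 200000 nM in this assay, at which 4 of the 4 values shown sit.

The compounds shown leave open how strongly any of the four inhibits, and whether their different groups change inhibition at all.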